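Swapping Bromines for Fluorines on the Anilide Ring

The source may hold more compounds than are shown below. What is called first, only, known or untested is meant among the compounds shown, and "the series" means these compounds.

Compound 3 `Cn1c(Cc2nn(C)c(=O)c3ccccc23)nnc1SCCCCCCCC(=O)Nc1ccc(Br)cc1Br` gives 1500 nM in an assay on isolated protein (Mus musculus) for inhibition of IL15-IL15 receptor (Homo sapiens), read by resazurin assay, with stated times of 30 min and 2.5 days; on this read-out lower numbers stand for stronger inhibition and higher numbers for weaker inhibition. Of the three measured compounds, compound 2 `CC(C)Oc1ccc(NC(=O)CCCCCCCSc2nnc(Cc3nn(C)c(=O)c4ccccc34)n2C)cc1` gives 1100 nM, and the step of a 1.4-fold higher number from compound 2 to compound 3 (0.13 log units; within the scatter) lies within the scatter, while compound 1 `CC(C)COc1ccc(NC(=O)CCCCCCCSc2nnc(Cc3nn(C)c(=O)c4ccccc34)n2C)cc1` gives 4800 nM, and the step of a 3.2-fold lower number from compound 1 to compound 3 (0.51 log units; beyond the scatter) lies beyond it. Compound 4 `Cn1c(Cc2nn(C)c(=O)c3ccccc23)nnc1SCCCCCCCC(=O)Nc1ccc(F)cc1F` differs from compound 3 by 2,4-difluorophenyl in place of 2,4-dibromophenyl on an amide-type nitrogen. The measured steps that touch the group on the amide-type nitrogen are a 3.2-fold lower number from compound 1 to compound 3 (0.51 log units; beyond the scatter) and a 1.4-fold higher number from compound 2 to compound 3 (0.13 log units; within the scatter); the step of a 4.4-fold lower number from compound 1 to compound 2 (0.64 log units; beyond the scatter) alters a different part. Among the measured compounds shown here, no measured pair exchanges one halogen for another, so compound 4 is expected to shift by a 1.7-fold higher number from compound 3 to compound 4 (0.22 log units; within the scatter), a step that may stay within the scatter. Compound 4 is estimated at 2500 nM, in the range 800 nM to 8000 nM.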

Compound 4, half-maximal inhibitory concentration: 2300 nM
For compound 4 the middle estimate is 1.1-fold (0.04 log units) above the measured one; measured number inside the range.
By their numbers in this assay, from the lowest: compounds 2, 3 and 4 (each within the scatter of the next, the first and the last beyond it); then compound 1.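

Exchanging one halogen for another on the amide-type nitrogen (a 1.5-fold higher number from compound 3 to compound 4 (0.19 log units; within the scatter)) leaves no readable difference between 2,4-difluorophenyl and 2,4-dibromophenyl. Yet 2,4-difluorophenyl does separate from both alkoxy-substituted rings, falling on the weaker side of 4-isopropoxyphenyl (a 2.1-fold higher number from compound 2 to compound 4 (0.32 log units; beyond the scatter)) and on the stronger side of 4-(isobutoxy)phenyl (a 2.1-fold lower number from compound 1 to compound 4 (0.32 log units; beyond the scatter)). No evidence here explains these steps. On these data alone, whether 2,4-dichlorophenyl or an unsubstituted phenyl would read the same at this position stays open, as does whether a single fluorine would suffice.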